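The source may report more compounds than this note shows. Statements on the series, on what has been measured and on what is new or still open speak of the compounds shown alone.

Measured so far:
compound 1 `COc1ccc(-n2c(C)nc3c(NC(C4CC4)C4CC4)nc(C)nc32)cc1`: 19 nM
compound 2 `Cc1nc(NC(C2CC2)C2CC2)c2nc(C)n(-c3ccc(Cl)cc3)c2n1`: 11 nM
compound 3 `Cc1nc(NC(C2CC2)C2CC2)c2nc(C)n(-c3ccc(OC(F)F)cc3Cl)c2n1`: 0.373 nM

In a functional assay on CHO cells for antagonist activity at corticotropin-releasing factor receptor 1 (Homo sapiens), read by cAMP accumulation (on this read-out higher numbers stand for weaker inhibition and lower numbers for stronger inhibition), compound 2 gives 11 nM and compound 1 gives 19 nM. The two differ by methoxy in place of chloro on an aromatic carbon, and that change made a 1.7-fold higher number from compound 2 to compound 1 (0.24 log units; within the scatter). Compound 3 gives 0.373 nM in this assay; the difference between its core and that of compound 2 is not broken down here.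

Compound 4 `COc1cc(OC(F)F)ccc1-n1c(C)nc2c(NC(C3CC3)C3CC3)nc(C)nc21` has not been measured. It differs from compound 3 by methoxy in place of chloro on an aromatic carbon. Going by the values given here, this is the same kind of change as the one from compound 2 to compound 1, but the place is not the same: there the methoxy enters para to a large group, here ortho to a large group and meta to a difluoromethoxy group. Because the earlier step was a 1.7-fold higher number from compound 2 to compound 1 (0.24 log units; within the scatter), a small step is expected here too, a 1.6-fold higher number from compound 3 to compound 4 (0.21 log units; within the scatter). Compound 4 is therefore estimated at 0.6 nM, between 0.2 nM and 2 nM.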

Compound 4, inhibition constant: 0.291 nM
Estimate against measurement, compound 4: 2.1-fold (0.31 log units) above; the measured number falls inside the stated range.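

The swap of chloro for methoxy made a 1.3-fold lower number from compound 3 to compound 4 (0.11 log units; within the scatter) in this assay, so the step is small on this core too. Set beside the earlier step, the two results do not differ: the same change on two cores in this assay, a 1.7-fold higher number (0.24 log units; within the scatter) from compound 2 to compound 1 and a 1.3-fold lower number (0.11 log units; within the scatter) from compound 3 to compound 4, 2.2-fold (0.35 log units) apart, within the scatter of two such steps

This supports carrying the swap between these two cores in this assay, but two pairs do not show that it would stay small on any other core or in any other test. The compounds shown leave open whether an amine, a carboxylic acid or a longer chain such as propoxy on the same aromatic carbon would also give only a small step.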